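Swapping a Fluorobenzyl Arm for Propyl on a Shared Core

This account rests on a few compounds, and the source may have more. Where it says the series, first, only, none or still open, it means among the compounds named here.

Three compounds share one core and differ only in the arm attached to the sulfur. Compound 1 `O=c1c2ccccc2[se]n1-c1nc(SCc2ccccc2)n[nH]1` carries a plain benzyl arm. In an ADME assay on L929 cells (Mus musculus) for antiproliferative activity, read by CCK-8 assay, with a stated time of 48 h (a lower number here means a stronger inhibitor, a higher number a weaker inhibitor), compound 1 gives only the assay limit of > 50000 nM, not a number. Compound 2 `Cc1ccc(CSc2n[nH]c(-n3[se]c4ccccc4c3=O)n2)cc1` adds a methyl on the ring, and in this assay compound 2 likewise stops at the limit, > 50000 nM. Compound 3 `O=c1c2ccccc2[se]n1-c1nc(SCc2ccc(F)cc2)n[nH]1` carries a fluorine instead, and in this assay compound 3 again reaches only the limit of > 50000 nM. Compound 3 therefore stands with the others at the limit, unranked. The steps a step that the two limits leave unreadable from compound 1 to compound 3 and a step that the two limits leave unreadable from compound 2 to compound 3 stay unreadable because of the limit of > 50000 nM in this assay, at which 3 of the 3 values shown sit. Compound 4 `CCCSc1n[nH]c(-n2[se]c3ccccc3c2=O)n1` brings a bigger change: ethyl in place of 4-fluorophenyl on a saturated chain carbon bound to a sulfur. Among the compounds with values here, no measured step bears on this change, so compound 4 is expected to remain at the limit, with an estimated 100000 nM (range 30000 nM to 300000 nM) and an expected step that the limit leaves unreadable from compound 3 to compound 4.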

Compound 4, half-maximal inhibitory concentration: 31800 nM
The estimate for compound 4 lay 3.1-fold (0.50 log units) above the measured number; the measured number falls inside the stated range.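

In this assay, within the data shown here, replacing the ring-bearing arm with propyl gives the first readable steps at this position: an at least 1.5-fold lower number from compound 3 to compound 4 (0.19 log units; that floor lies within the scatter), an at least 1.5-fold lower number from compound 2 to compound 4 (0.19 log units; that floor lies within the scatter) and an at least 1.5-fold lower number from compound 1 to compound 4 (0.19 log units; that floor lies within the scatter). Each step is only a floor on the change, not its size, and that floor lies within the scatter, so propyl cannot yet be said to outperform the benzyl-type arms: the limit of > 50000 nM in this assay, at which 3 of the 4 values shown sit.

The compounds shown do not separate the loss of the aromatic ring from the shortening of the arm. On these data alone, whether a longer chain or an amine in place of propyl would lower the number further also stays open.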